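The compounds below may be only part of what the source reports. "The series", "measured", "known", "first", "only" and "open" are said of these compounds alone.

Values in a functional assay on CNE cells (Homo sapiens) for cytotoxicity, read by MTT assay, with a stated time of 72 h (on this read-out higher numbers stand for weaker inhibition and lower numbers for stronger inhibition), so far:
- compound 1 `COc1ccc(CCCOC(=O)CCc2ccc(O)cc2)cc1` gives 287000 nM
- compound 2 `O=C(CCc1ccc(O)c(O)c1)OCCCc1ccccc1` gives 235000 nM

Compound 2 stands level with compound 1, as the two values lie within the scatter of each other. Compound 3 `O=C(CCc1ccc(O)cc1)OCCCc1ccccc1` differs from compound 2 at one place (hydrogen in place of hydroxy on an aromatic carbon): hydrogen in place of hydroxy on an aromatic carbon, ortho to a hydroxy group. For the measured compounds named here, no measured pair isolates this change in this assay, so the expectation is no step beyond the scatter, in either direction. The nearest guide is compound 1 (287000 nM), which also has a single hydroxy group but carries a methoxy group that compound 3 lacks. The expected change is a 1.2-fold higher number from compound 2 to compound 3 (0.08 log units; within the scatter), which would stay within the scatter. For compound 3 the estimated value is 280000 nM, with an expected range from 130000 nM to 600000 nM.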

Compound 3, half-maximal inhibitory concentration: 268000 nM
Estimate against measurement, compound 3: 1.0-fold (0.02 log units) above; measured number inside the range.
By their numbers in this assay, from the lowest: compounds 2, 3 and 1 (each within the scatter of the next).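

In this assay, for the compounds shown here, hydrogen in place of hydroxy on an aromatic carbon, ortho to a hydroxy group, gives a 1.1-fold higher number from compound 2 to compound 3 (0.06 log units; within the scatter), the first direct reading of this position, and it shows no step beyond the scatter. Hydrogen in place of methoxy on an aromatic carbon gives a 1.1-fold lower number from compound 1 to compound 3 (0.03 log units; within the scatter), so this second single change also stays within the scatter, and compound 3 now links compound 1 and compound 2 by one-place steps. No measurement on hand bears on why these steps are so small.

As far as these compounds go, only hydroxy, methoxy and hydrogen are covered at these places, so the effect of an amine or a carboxylic acid on the aromatic ring stays open. From the compounds shown here alone, whether a longer chain in the shared core would give a step beyond the scatter also stays open.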